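The compounds below may be only part of what the source reports. "The series", "measured", "known", "first", "only" and "open" are said of these compounds alone.

Working notes on the series. Compound 1 `CC(C)(C)CNC(=O)C[C@H](NC(=O)CCc1ccccc1)C(=O)N[C@@H](CCc1ccccc1)C(=O)NCc1ccccc1` gives 12 nM in an assay on HEK293 cells for inhibition of nuclear factor NF-kappa-B complex (Homo sapiens), read by a luciferase reporter, with stated times of 1 h and 3 h; a lower number here means a stronger inhibitor, a higher number a weaker inhibitor. Compound 2 `CC(C)(C)CNC(=O)C[C@H](NC(=O)C(=O)c1c[nH]c2ccccc12)C(=O)N[C@@H](CCc1ccccc1)C(=O)NCc1ccccc1` gives 25 nM in this assay; the step of a 2.1-fold higher number from compound 1 to compound 2 (0.32 log units; beyond the scatter) is modest. Compound 3 `CC(C)(C)CNC(=O)C[C@H](NC(=O)CCc1ccccc1)C(=O)N[C@@H](CCc1ccccc1)C(=O)NCC1CC1` gives 38 nM in this assay, and the step of a 3.2-fold higher number from compound 1 to compound 3 (0.50 log units; beyond the scatter) is the larger of the two shown. Compound 3 therefore sits beyond the scatter from compound 1, while its gap to compound 2 lies within the scatter.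

Compound 4 `CC(C)(C)CNC(=O)C[C@H](NC(=O)CCc1ccccc1)C(=O)N[C@@H](CCc1ccccc1)C(=O)NCc1ccccc1Cl` is not yet measured. It differs from compound 3 by 2-chlorophenyl in place of cyclopropyl on a saturated chain carbon bound to an amide-type nitrogen. Among the compounds with values here, the one measured step that bears on this change is a 3.2-fold higher number from compound 1 to compound 3 (0.50 log units; beyond the scatter), which runs the other way at the same place; compound 4 undoes that change and adds a chlorine to the benzyl ring. The expectation is that the number falls back toward that of compound 1, so a step of about a 2.5-fold lower number from compound 3 to compound 4 (0.40 log units; beyond the scatter) is estimated. Compound 4 is accordingly expected to give about 15 nM in this assay, within a range from 6 nM to 40 nM.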

Compound 4, half-maximal inhibitory concentration: 18 nM
Beside the measured number, compound 4's estimate is 1.2-fold (0.08 log units) below it; the range from low to high includes it.
By their numbers in this assay, from the lowest: compounds 1, 4, 2 and 3 (each within the scatter of the next, the first and the last beyond it).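

In this assay, the change from cyclopropyl to 2-chlorophenyl on a saturated chain carbon bound to an amide-type nitrogen gives (a 2.1-fold lower number from compound 3 to compound 4 (0.32 log units; beyond the scatter)), so an aromatic ring at this position is tolerated even when it carries a chlorine. The comparison with the unsubstituted ring, chloro in place of hydrogen on an aromatic carbon, gives (a 1.5-fold higher number from compound 1 to compound 4 (0.18 log units; within the scatter)), which lies within the scatter, so this chlorine has no effect that can be separated from assay noise. No measured evidence accounts for either step.

The compounds shown leave open whether a methoxy group or a carboxylic acid on the same ring would also keep the number within the scatter of compound 1. They also leave open how a longer chain carrying the ring would read at this position.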